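The source may report more compounds than this note shows. Statements on the series, on what has been measured and on what is new or still open speak of the compounds shown alone.

Working notes on the series, read in a functional assay on HeLa cells (Homo sapiens) for antiproliferative activity, read by MTT assay, with a stated time of 24 h; on this read-out lower numbers stand for stronger inhibition and higher numbers for weaker inhibition. Among the compounds with values here, compound 1 (`Cc1ccc(-c2nn(-c3ccccc3)cc2-c2nc3ccccc3n2S(=O)(=O)c2ccccc2)cc1`) gives 820 nM and compound 2 (`Cc1ccc(-c2nn(-c3ccccc3)cc2-c2nc3ccccc3n2S(=O)(=O)c2cc(C)ccc2C)cc1`) gives 370 nM as the lower of the two numbers so far. Compound 3 (`Cc1ccc(-c2nn(-c3ccccc3)cc2-c2nc3ccccc3n2S(=O)(=O)c2ccc(F)cc2)cc1`) differs from compound 2 by the change 4-fluorophenyl in place of 2,5-dimethylphenyl on a sulfonyl sulfur with 4-fluorophenyl in place of 2,5-dimethylphenyl on a sulfonyl sulfur. Within the data shown here, the only measured step at this place is modest: a 2.2-fold lower number from compound 1 to compound 2 (0.35 log units; beyond the scatter) on going to 2,5-dimethylphenyl. Among the measured compounds shown here, no 4-fluorophenyl member has a number yet, so a modest move back toward compound 1 is expected. The expected change is a 1.5-fold higher number from compound 2 to compound 3 (0.18 log units; within the scatter) toward a higher number. Compound 3 is estimated at 560 nM within a range of 230 nM to 1300 nM in this assay.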

Compound 3, half-maximal inhibitory concentration: 3670 nM
Estimate against measurement, compound 3: 6.6-fold (0.82 log units) below, outside the stated range (above it).
By their numbers in this assay, from the lowest: compound 2; then compound 1; then compound 3.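

In this assay this position, on a sulfonyl sulfur, proves more sensitive than the first step indicated: 4-fluorophenyl in place of 2,5-dimethylphenyl gives a 9.9-fold higher number from compound 2 to compound 3 (1.00 log units; beyond the scatter) and takes the number past that of the phenyl member. Fluoro in place of hydrogen on an aromatic carbon gives a 4.5-fold higher number from compound 1 to compound 3 (0.65 log units; beyond the scatter) on its own, so the two substituted rings move the number in opposite directions. Nothing available bears on the cause of this result.

From the compounds shown here alone, whether the loss follows fluorine itself or its ring position remains open. So does whether a single methyl carries the gain of compound 2, and whether a chloro or methoxy group would follow either direction.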